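From sec-butyl to cyclohexyl on the amine nitrogen

The source may report more compounds than this note shows. Statements on the series, on what has been measured and on what is new or still open speak of the compounds shown alone.

Of the compounds shown here, two sharing one core have been measured in a functional assay on CHO-K1 cells (Cricetulus griseus) for inhibition, read by MTT assay, with a stated time of 72 h; on this read-out higher numbers stand for weaker inhibition and lower numbers for stronger inhibition. Compound 1 (`CC(C)CNC(=C\C(=O)/C=C/c1ccc(O)cc1)/C=C/c1ccc(O)cc1`) gives 17900 nM and compound 2 (`CCC(C)NC(=C\C(=O)/C=C/c1ccc(O)cc1)/C=C/c1ccc(O)cc1`) gives 13100 nM, and these two values lie within the scatter of each other. Compound 2 therefore stands level with compound 1, and no other number is yet available for comparison. The next compound, compound 3 (`O=C(/C=C(/C=C/c1ccc(O)cc1)NC1CCCCC1)/C=C/c1ccc(O)cc1`), carries cyclohexyl in place of sec-butyl on an amine nitrogen. Among the compounds with values here, only one measured step bears on this change, the exchange of isobutyl for sec-butyl on an amine nitrogen, which amounts to a 1.4-fold lower number from compound 1 to compound 2 (0.14 log units; within the scatter). That step stays within the scatter, but no ring enters in it, so it offers only indirect guidance here. The data support no expectation of a step beyond the scatter in either direction. The expected change is a 1.1-fold lower number from compound 2 to compound 3 (0.04 log units; within the scatter). Compound 3 is estimated at 12000 nM, with an expected range from 5500 nM to 26000 nM.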

Compound 3, half-maximal inhibitory concentration: 9200 nM
Compound 3: the middle estimate sits 1.3-fold (0.12 log units) above what was measured, and the stated range covers the measured number.
By their numbers in this assay, from the lowest: compounds 3, 2 and 1 (each within the scatter of the next).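

In this assay the exchange of an open chain for a ring at this position gives a 1.4-fold lower number from compound 2 to compound 3 (0.15 log units; within the scatter) and, measured against the isobutyl compound, a 1.9-fold lower number from compound 1 to compound 3 (0.29 log units; within the scatter) so neither step leaves the scatter. Until now only open four-carbon groups had been seen on this amine nitrogen; compound 3 adds a cyclohexyl, with its six-membered non-aromatic ring of carbon only, and the read-out stays level with the values of both earlier compounds. Nothing measured here accounts for how close the three values lie.

What the compounds leave open is whether any group on this nitrogen can move the number beyond the scatter at all, since isobutyl, sec-butyl and cyclohexyl are all made of carbon alone and bring no hydrogen-bond donor or acceptor. A phenyl or benzyl group, a chain ending in a carboxylic acid or an amine, or the unsubstituted amino group would test that question, and the compounds shown say nothing about how any of these would read in this assay here.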